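A few compounds are considered here, and "the series" means these few. Any claim that something is new, unique, unknown or untested is made for them only; others in the source may bear on it.

Measured compounds and their values:

Compound 1 `N#Cc1ccc(Nc2nccc(Oc3ccc(-c4ccc(C#N)cc4)cc3F)n2)cc1`: in a functional assay on MT4 cells (Homo sapiens) for cytotoxicity, read by MTT assay, with a stated time of 5 days (on this read-out higher numbers stand for lower toxicity in this test and lower numbers for higher toxicity in this test), compound 1 gives > 307000 nM, which is a limit of the assay.
Compound 2 `COc1cc(-c2ccc(C#N)cc2)ccc1Oc1ccnc(Nc2ccc(C#N)cc2)n1`: in this assay compound 2 gives > 298000 nM, again a limit.
Compound 3 `Cc1cc(-c2ccc(C#N)cc2)ccc1Oc1ccnc(Nc2ccc(C#N)cc2)n1`: in this assay compound 3 gives > 310000 nM, once more a limit.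

Compound 3 thus stands at a limit only, and the two other values shown are limits as well, so no ranking among the three is possible. The steps between the measured compounds are a step that the two limits leave unreadable from compound 1 to compound 2, a step that the two limits leave unreadable from compound 1 to compound 3 and a step that the two limits leave unreadable from compound 2 to compound 3; the limits (the limit of > 298000 nM in this assay, at which 1 of the 3 values shown sits), the limit of > 307000 nM in this assay, at which 1 of the 3 values shown sits, and the limit of > 310000 nM in this assay, at which 1 of the 3 values shown sits, leave each of them without a readable size.

The unmeasured compound 4 `N#Cc1ccc(Nc2nccc(Oc3ccc(-c4ccc(C#N)cc4)cc3C(F)(F)F)n2)cc1` differs from compound 3 by trifluoromethyl in place of methyl on an aromatic carbon. Among the compounds with values here, the two measured steps that end at compound 3, a step that the two limits leave unreadable from compound 1 to compound 3 and a step that the two limits leave unreadable from compound 2 to compound 3, concern the same position, but neither yields a size, so no direction and no magnitude can be drawn from them beyond the observation that every change at this position so far has left the value at a limit. No step beyond the scatter is therefore expected in this assay.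

Compound 4 is estimated to give 280000 nM in this assay, most likely again as a limit, with a range from 90000 nM to 400000 nM. The step this estimate implies, an at least 1.1-fold lower number from compound 3 to compound 4 (0.04 log units; that floor lies within the scatter), is an expectation and not a measurement.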

Compound 4, half-maximal cytotoxic concentration: > 273000 nM
Compound 4 gave a limit, no number (the forecaster's own chance of this, stated with the estimate: 80%); the middle value lies beyond the limit too.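

In this assay compound 4 gives > 273000 nM, which is a limit of the assay. Compound 1, compound 2 and compound 3 also stand at limits, so none of the steps linking them to compound 4 can be read. The compounds shown leave open what half-maximal cytotoxic concentration each actually has, and whether changing the group at this position alters it.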